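Series notes: sugar-chain imidazoles and in vivo clearance

The source may report more compounds than this note shows. Statements on the series, on what has been measured and on what is new or still open speak of the compounds shown alone.

Measured so far:
compound 1 `CC(O)c1nc([C@@H](O)[C@H](O)[C@H](O)CO)c[nH]1`: 16.4 mL/min/kg
compound 2 `OC[C@@H](O)[C@@H](O)[C@H](O)c1c[nH]c(C(F)(F)C(F)(F)F)n1`: 1.3 mL/min/kg

Both compounds share a core carrying the same polyhydroxylated chain and differ only in the group on the remaining aromatic carbon of that core. In an in vivo ADME assay on the whole organism (strain 129/SvEvBrd x C57BL/6) for pharmacokinetics, with Mus musculus as the target, at a dose of 1 mg/kg by the intravenous route (a lower number here means slower removal, a higher number faster removal of the compound), compound 1 gives 16.4 mL/min/kg, the higher of the two numbers; compound 2 gives 1.3 mL/min/kg, and the gap between them lies beyond the usual scatter. Among the measured compounds shown here, no step between measured compounds exists that matches the change considered next, so nothing measured speaks directly to it.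

Compound 3 `Cn1cnc(-c2nc([C@@H](O)[C@H](O)[C@H](O)CO)c[nH]2)c1` is the next compound. It differs from compound 1 as follows: 1-methyl-1H-imidazol-4-yl in place of 1-hydroxyethyl on an aromatic carbon. For the measured compounds named here, the only anchor is the pair of values from compound 1 and compound 2, which shows that the group on this carbon can move the clearance a long way, but in an unrelated direction of structural change. For compound 3 a step of a 1.4-fold lower number from compound 1 to compound 3 (0.14 log units; within the scatter) is expected, modest and within the scatter, with the number staying nearer compound 1 than compound 2. The estimate for compound 3 in this assay is 12 mL/min/kg, with a range from 4 mL/min/kg to 35 mL/min/kg.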

Compound 3, clearance: 9.1 mL/min/kg
The estimate for compound 3 lay 1.3-fold (0.12 log units) above the measured number, and the stated range covers the measured number.
By their numbers in this assay, from the lowest: compound 2; then compounds 3 and 1 (each within the scatter of the next).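

In this assay, among the compounds shown here, the change from 1-hydroxyethyl to 1-methyl-1H-imidazol-4-yl gives a 1.8-fold lower number from compound 1 to compound 3 (0.26 log units; within the scatter) and is the first step read directly at this aromatic carbon, between two ring nitrogen atoms. The change is a large one on paper, with 6 heavy atoms and one five-membered aromatic ring entering where 3 heavy atoms and no ring leave, and with 0 hydrogen-bond donors in place of 1, yet the step stays within the scatter, so in this single pair that exchange brings no readable shift in clearance. Nothing measured here bears on why the two compounds sit so close.

As far as these compounds go, it remains open whether a different group on this carbon, such as an amine, a carboxylic acid or an unsubstituted phenyl ring, would stay with compound 1 and compound 3 or come closer to compound 2 at 1.3 mL/min/kg. From the compounds shown here alone, it is also open whether the step from 1-hydroxyethyl to 1-methyl-1H-imidazol-4-yl would look the same with a shorter polyhydroxylated chain on the shared core.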